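Swapping the halogenated aniline for a trifluoromethyl one

The source may hold more compounds than are shown below. What is called first, only, known or untested is meant among the compounds shown, and "the series" means these compounds.

Of the compounds shown here, three built on one shared core have been tested in a functional assay on NCI-H1975 cells (Homo sapiens) for antiproliferative activity, read by MTT assay, with a stated time of 72 h; on this read-out lower numbers stand for stronger inhibition and higher numbers for weaker inhibition. Compound 1 `COc1cc2ncnc(Nc3ccc(Br)cc3)c2cc1OCCCCC(=O)Nc1ccc(S(N)(=O)=O)cc1` gives 23300 nM. Compound 2 `COc1ccc(Nc2ncnc3cc(OC)c(OCCCCC(=O)Nc4ccc(S(N)(=O)=O)cc4)cc23)cc1OC` gives 9230 nM, and compound 3 `COc1cc2ncnc(Nc3ccc(F)c(Br)c3)c2cc1OCCCCC(=O)Nc1ccc(S(N)(=O)=O)cc1` gives 31600 nM. Compound 3 thus shows the largest number of the three, although a 1.4-fold higher number from compound 1 to compound 3 (0.13 log units; within the scatter) keeps it level with compound 1; the clearer gap is a 3.4-fold higher number from compound 2 to compound 3 (0.53 log units; beyond the scatter), which mirrors a 2.5-fold lower number from compound 1 to compound 2 (0.40 log units; beyond the scatter).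

Compound 4 `COc1cc2ncnc(Nc3ccc(C(F)(F)F)cc3)c2cc1OCCCCC(=O)Nc1ccc(S(N)(=O)=O)cc1` has not yet been measured. It differs from compound 3 by 4-(trifluoromethyl)phenyl in place of 3-bromo-4-fluorophenyl on a nitrogen on an aromatic ring. Within the data shown here, no measured step makes this exact exchange. Among the measured compounds shown here, the nearest comparison, a 1.4-fold higher number from compound 1 to compound 3 (0.13 log units; within the scatter), altered only the halogen pattern on the same ring without leaving the scatter, whereas the single step beyond the scatter, a 2.5-fold lower number from compound 1 to compound 2 (0.40 log units; beyond the scatter), brought in a 3,4-dimethoxyphenyl group that compound 4 does not carry. The step expected from this exchange is a 1.2-fold lower number from compound 3 to compound 4 (0.08 log units; within the scatter). The estimate for compound 4 in this assay is 26000 nM, within a range from 11000 nM to 60000 nM.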

Compound 4, half-maximal inhibitory concentration: 12000 nM
Compound 4: the middle estimate sits 2.2-fold (0.34 log units) above what was measured, and the stated range covers the measured number.
By their numbers in this assay, from the lowest: compounds 2, 4, 1 and 3 (each within the scatter of the next, the first and the last beyond it).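

In this assay, 4-(trifluoromethyl)phenyl in place of 3-bromo-4-fluorophenyl on the nitrogen gives a step beyond the scatter (a 2.6-fold lower number from compound 3 to compound 4 (0.42 log units; beyond the scatter)), so a change of this size at this position does not require the methoxy groups of the earlier 3,4-dimethoxyphenyl example. The new group cannot be separated from either of the other two groups (a 1.3-fold higher number from compound 2 to compound 4 (0.11 log units; within the scatter) and a 1.9-fold lower number from compound 1 to compound 4 (0.29 log units; within the scatter)), and since compound 1 also lies within the scatter of compound 3, these small gaps give only a loose ranking. Nothing measured here explains this difference.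

From the compounds shown here alone, how a nitrile, an amine or a carboxylic acid in place of trifluoromethyl on this ring would read remains open. So does the effect of a longer chain on the shared core of compound 4.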